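Replacing the amide of compound 1 with a methylsulfonyloxy group

The compounds below may be only part of what the source reports. "The series", "measured", "known", "first", "only" and "open" are said of these compounds alone.

Measured so far:
- compound 1 `CN1CCC(c2c[nH]c3ccc(NC(=O)C4CC4)nc23)CC1` gives 1800 nM in an assay for binding affinity to 5-hydroxytryptamine receptor 1D (Homo sapiens), read by radioligand binding; a lower number here means a stronger inhibitor, a higher number a weaker inhibitor
- compound 2 `CN1CCC(c2c[nH]c3ccc(NC(=O)c4cccc(F)c4)nc23)CC1` gives 690 nM in this assay
- compound 3 `CN1CCC(c2c[nH]c3ccc(NC(=O)c4ccc([N+](=O)[O-])cc4)nc23)CC1` gives 340 nM in this assay

Among these three, compound 1 has the highest number and therefore the weakest binding: the nearest is a 2.6-fold lower number from compound 1 to compound 2 (0.42 log units; beyond the scatter), the furthest a 5.3-fold lower number from compound 1 to compound 3 (0.72 log units; beyond the scatter). Between the two aryl amides there is a 2.0-fold lower number from compound 2 to compound 3 (0.31 log units; beyond the scatter).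

Compound 4 `CN1CCC(c2c[nH]c3ccc(OS(C)(=O)=O)nc23)CC1` differs from compound 1 in one place: (methylsulfonyl)oxy in place of (cyclopropylcarbonyl)amino on an aromatic carbon. For the measured compounds named here, none of the measured steps touches this change. All three keep the amide and vary only the group on its carbonyl carbon, and those exchanges moved the numbers by modest amounts. Going by the values given here, the sulfonate of compound 4 has no measured counterpart, so its direction can only be guessed; the safest expectation is a number close to compound 1, with wide uncertainty on both sides.

For compound 4 the expected value in this assay is therefore 2000 nM, within 500 nM to 8000 nM, which as a step would mean a 1.1-fold higher number from compound 1 to compound 4 (0.05 log units; within the scatter).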

Compound 4, inhibition constant: 8 nM
Estimate against measurement, compound 4: 250-fold (2.40 log units) above; the measured number lies below the stated range.
By their numbers in this assay, from the lowest: compound 4; then compound 3; then compound 2; then compound 1.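

For the compounds shown here, the group on this aromatic carbon matters far more than the earlier compounds showed. In this assay, exchanging the whole (cyclopropylcarbonyl)amino group for (methylsulfonyl)oxy gives a 230-fold lower number from compound 1 to compound 4 (2.35 log units; beyond the scatter), a step well beyond the largest exchange on the carbonyl carbon, which is a 5.3-fold lower number from compound 1 to compound 3 (0.72 log units; beyond the scatter), so the amide itself need not be kept for binding at this receptor. No measurement at hand explains why this exchange has so large an effect.

The compounds shown leave open whether the whole sulfonate is needed, which a methoxy group or a sulfonamide, with nitrogen in place of the linking oxygen, on the same carbon could test. They also leave open how much room there is on the sulfur, which an ethyl or longer chain in place of the methyl could probe.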